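The source may report more compounds than this note shows. Statements on the series, on what has been measured and on what is new or still open speak of the compounds shown alone.

Compound 1 `CC(Cc1ccc(Cl)cc1Cl)C(=O)NCc1ccc(F)cc1`: "not determined" (no result reported)
Compound 2 `CCCC(NC(=O)C(C)Oc1ccc(Cl)cc1Cl)c1ccc(F)cc1`: > 100000 nM

Among the compounds with values here, only two compounds have been taken into an ADME assay on CHO cells (Cricetulus griseus) for cytotoxicity, read by LDH release (a lower number here means a stronger inhibitor, a higher number a weaker inhibitor), and neither yields a usable number. For compound 1 the entry reads "not determined" (no result reported). Compound 2 gives > 100000 nM, which is a limit of the assay and not a number. Within the data shown here, that makes the limit of > 100000 nM in this assay, at which 1 of the 2 values shown sits, the only firm reference point, and no step between measured compounds is available as a guide.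

Compound 3 `CC(Oc1ccc(Cl)cc1Cl)C(=O)NC(c1ccc(F)cc1)C1CCC1` follows from compound 2 through one change: cyclobutyl in place of propyl on a saturated chain carbon bound to an amide-type nitrogen and an aromatic carbon. In words, this is cyclobutyl in place of propyl on a saturated chain carbon bound to an amide-type nitrogen and an aromatic carbon.

The expected move in this assay, a number no higher from compound 2 to compound 3 (the limit leaves the size open), is none beyond the scatter, in either direction. The estimate for compound 3 is 100000 nM, with an expected range from 40000 nM to 150000 nM.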

Compound 3, half-maximal inhibitory concentration: > 100000 nM
Compound 3 gave a limit, no number; the forecaster's own chance of this, stated with the estimate: 85%; the middle value lies on the limit itself.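

In this assay compound 3 gives > 100000 nM, which is a limit of the assay and not a number. Compound 2 also stands at a limit, so no step can be read between compound 2 and compound 3. The compounds shown leave open whether cyclobutyl in place of propyl changes the read-out at all, and the only reference point remains: the limit of > 100000 nM in this assay, at which 2 of the 3 values shown sit.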